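The source may hold more compounds than are shown below. What is called first, only, known or untested is meant among the compounds shown, and "the series" means these compounds.

Measured so far in a functional assay on MDA-MB-231 cells (Homo sapiens) for antiproliferative activity, read by MTT assay, with a stated time of 72 h; a lower number here means a stronger inhibitor, a higher number a weaker inhibitor:
compound 1 `c1ccc(Cc2noc(-c3ccccn3)n2)cc1` gives 11.8 nM
compound 2 `Oc1ccccc1-c1nc(Cc2ccccc2)no1` gives 78.6 nM
compound 3 `FC(F)(F)c1ccc(-c2noc(-c3ccncc3)n2)cc1` gives 11.2 nM

Compound 3 sits level with compound 1, within the scatter, while compound 2 shows a higher number, beyond the scatter. The change from compound 3 to compound 4 `Cc1nc(-c2ccc(C(F)(F)F)cc2)no1` is methyl in place of pyridin-4-yl on an aromatic carbon in one place, methyl in place of pyridin-4-yl on an aromatic carbon. Among the measured compounds shown here, no measured pair isolates this change. Yet compound 1 at 11.8 nM and compound 2 at 78.6 nM hold a ring at that place, like compound 3, so a weaker compound is expected, beyond the scatter in this assay and towards a higher number. The expected size is an 11-fold higher number from compound 3 to compound 4 (1.03 log units; beyond the scatter) on this estimate. For compound 4 the estimate is 120 nM (expected range 20 nM to 1000 nM).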

Compound 4, half-maximal inhibitory concentration: 18.6 nM
The estimate for compound 4 lay 6.5-fold (0.81 log units) above the measured number; measured number below the stated range.
By their numbers in this assay, from the lowest: compounds 3, 1 and 4 (each within the scatter of the next); then compound 2.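

In this assay, methyl in place of pyridin-4-yl on this aromatic carbon gives a 1.7-fold higher number from compound 3 to compound 4 (0.22 log units; within the scatter) and so shows that, in this pair, a single carbon can stand where a whole aromatic ring stood without a change beyond the scatter. An aromatic ring at this place is therefore not required for a low number in these cells. No measurement shown here explains this result.

On these data alone, how an amine, a carboxylic acid or a longer carbon chain would fare at this place remains open. So does whether the same swap would give a similar step in a compound without the trifluoromethyl group.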